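The compounds below may be only part of what the source reports. "The series", "measured", "known", "first", "only" and "open" are said of these compounds alone.

Measured in a functional assay on HepG2 cells (Homo sapiens) for antiproliferative activity, read by XTT assay, with a stated time of 72 h (a higher number here means a weaker inhibitor, a lower number a stronger inhibitor), limits only:
- compound 1 `CSc1ncnc2c1c(-c1ccsc1)cn2[C@@H]1O[C@H](CO)[C@@H](O)[C@H]1O`: > 15000 nM
- compound 2 `Nc1nc(N)c2c(-c3ccsc3)cn([C@@H]3O[C@H](CO)[C@@H](O)[C@H]3O)c2n1`: > 20000 nM
- compound 3 `Cc1nc(N)c2c(-c3ccsc3)cn([C@@H]3O[C@H](CO)[C@@H](O)[C@H]3O)c2n1`: > 20000 nM

Compound 3 has no number, only the limit > 20000 nM. Among the measured compounds shown here, the series so far gives nothing but limits: the limit of > 15000 nM in this assay, at which 1 of the 3 values shown sits, and (the limit of > 20000 nM in this assay, at which 2 of the 3 values shown sit).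

The next compound is compound 4 `Cc1nc(N)c2c(I)cn([C@@H]3O[C@H](CO)[C@@H](O)[C@H]3O)c2n1`, with iodo in place of thiophen-3-yl on an aromatic carbon. For the measured compounds named here, the one measured step, a step that the two limits leave unreadable from compound 2 to compound 3, has no readable size and concerns a different exchange, methyl in place of amino, so it gives no guide here. All three measured compounds carry thiophen-3-yl, and none shows what iodo does in this series.

The expectation therefore rests on compound 3 and its limit of > 20000 nM. In this assay no clear step can be derived, so compound 4 is expected to stay weak, possibly again reported only as a limit, with the range left open toward stronger inhibition. The expected step is an at least 1.4-fold lower number from compound 3 to compound 4 (0.15 log units; that floor lies within the scatter). For compound 4 the estimate is 14000 nM, with an expected range of 1500 nM to 20000 nM.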

Compound 4, half-maximal inhibitory concentration: 6310 nM
For compound 4 the middle estimate is 2.2-fold (0.35 log units) above the measured one, and the stated range covers the measured number.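

In this assay, iodo in place of thiophen-3-yl on this aromatic carbon gives an at least 3.1-fold lower number from compound 3 to compound 4 (0.50 log units; beyond the scatter). The position two ring bonds from the ring nitrogen therefore responds to its substituent, and compound 4 is the first compound shown with a number rather than a limit. Compound 3 holds only a limit, > 20000 nM, so the step is a floor, and the other limit shown in this series is of the same kind: the limit of > 20000 nM in this assay, at which 2 of the 4 values shown sit.

As far as these compounds go, only thiophen-3-yl and iodo are compared at this position, on the core carrying methyl, so it remains open whether bromo, a nitrile or an ethynyl group would behave like iodo. The step between amino and methyl cannot be read from its two limits, which leaves open how iodo would fare with amino in place of methyl.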